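The compounds below may be only part of what the source reports. "The series", "measured", "known", "first", "only" and "open" are said of these compounds alone.

Working notes on the series. Going by the values given here, in a functional assay on HCT-116 cells (Homo sapiens) for inhibition, read by sulforhodamine B assay, with a stated time of 48 h, tested at 50 uM (a higher number here means more inhibition of growth at the concentration tested, a lower number less inhibition of growth), compound 1 (`COc1cc(/C=C/C(=O)/C=C/c2cc(OC)c(OC)c(OC)c2)ccc1OCc1cn(CCOc2cc(=O)oc3ccccc23)nn1`) gives 89% and holds the highest of the two numbers so far. Compound 2 (`COc1ccc(/C=C/C(=O)/C=C/c2ccc(OCc3cn(CCCOc4cc(=O)oc5ccccc45)nn3)c(OC)c2)cc1OC`) gives 67% and sits lower, by a gap beyond the usual scatter. These two compounds differ in more than one place, so their gap is not a single-change step.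

Among the compounds with values here, compound 3 (`COc1ccc(/C=C/C(=O)/C=C/c2ccc(OCc3cn(CCOc4cc(=O)oc5ccccc45)nn3)c(OC)c2)cc1`) has no measurement yet and departs from compound 1 in one place: 4-methoxyphenyl in place of 3,4,5-trimethoxyphenyl on a double-bonded chain carbon bound to a double-bonded chain carbon. Within the data shown here, no measured single-place step is available to calibrate this change. In this assay a downward move of moderate size, somewhat beyond the scatter, is expected, since compound 1 at 89% leaves little room upward and compound 2 at 67% shows how far a related compound can lie below it. The estimated change is a number 17 percentage points lower from compound 1 to compound 3 (beyond the scatter) on this limited evidence. The estimate for compound 3 is 72% (expected range 50% to 92%).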

Compound 3, percent growth inhibition at one concentration: 71%
For compound 3 the middle estimate is 1 percentage points above the measured one; measured number inside the range.
By their numbers in this assay, from the lowest: compounds 2 and 3 (each within the scatter of the next); then compound 1.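

In this assay the series now has its first single-place step: a number 18 percentage points lower from compound 1 to compound 3 (beyond the scatter) when 4-methoxyphenyl stands in place of 3,4,5-trimethoxyphenyl on a double-bonded chain carbon bound to a double-bonded chain carbon. The earlier pair could not show this, as compound 1 and compound 2 differ in more than one place; this step shows that growth inhibition at the tested concentration responds to the aryl group at this position, with the 3,4,5-trimethoxyphenyl compound giving the higher number of this pair. No measurement at hand accounts for the size of this step, which stands as an observation from one pair of compounds.

Open, from the compounds shown here alone, is whether a different group at this place, such as 4-hydroxyphenyl or 4-dimethylaminophenyl, would move the number further in either direction, and how much of the step follows from any single methoxy group. Compound 2 departs from compound 1 and compound 3 in more than one place, so its number cannot be read as the effect of any one change.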